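The source may hold more compounds than are shown below. What is called first, only, known or untested is meant among the compounds shown, and "the series" means these compounds.

Among the measured compounds shown here, compound 1 `CN(C)CCn1cnnc1-c1cc(Oc2ccc(NC(=O)N/N=C/c3c[nH]c4ccccc34)cc2F)ccn1` is one of two compounds measured in a functional assay on HT-29 cells (Homo sapiens) for cytotoxicity, read by MTT assay, with a stated time of 72 h; on this read-out higher numbers stand for weaker inhibition and lower numbers for stronger inhibition. In this assay compound 1 gives 1300 nM, and the other measured compound, compound 2 `CN(C)CCn1cnnc1-c1cc(Oc2ccc(NC(=O)N/N=C/c3ccccc3)cc2F)ccn1`, sits within the scatter of it: compound 2 gives 1120 nM. The step from compound 1 to compound 2 was a 1.2-fold lower number from compound 1 to compound 2 (0.06 log units; within the scatter), for phenyl in place of 1H-indol-3-yl on a carbon with a double bond to nitrogen.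

Compound 3 `CN(C)CCn1cnnc1-c1cc(Oc2ccc(NC(=O)N/N=C/c3ccc(F)cc3F)cc2F)ccn1` has not yet been measured. It differs from compound 1 by 2,4-difluorophenyl in place of 1H-indol-3-yl on a carbon with a double bond to nitrogen. For the measured compounds named here, the measured step that bears on this change is the one from compound 1 to compound 2, which removed the same 1H-indol-3-yl group in favour of a phenyl and stayed within the scatter. Going by the values given here, compound 3 carries 2,4-difluorophenyl rather than plain phenyl, and no measured pair shows what this difluoro pattern does in this assay. The step expected from compound 1 to compound 3 is therefore small, a 1.2-fold lower number from compound 1 to compound 3 (0.07 log units; within the scatter), with no direction beyond the scatter. Compound 3 is accordingly estimated at 1100 nM in this assay, with a range from 400 nM to 3000 nM.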

Compound 3, half-maximal inhibitory concentration: 960 nM
The estimate for compound 3 lay 1.1-fold (0.06 log units) above the measured number; low and high end bracket the measured number.
By their numbers in this assay, from the lowest: compounds 3, 2 and 1 (each within the scatter of the next).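

Placing 2,4-difluorophenyl on the carbon with a double bond to nitrogen, in place of 1H-indol-3-yl, gives a 1.4-fold lower number from compound 1 to compound 3 (0.13 log units; within the scatter) in this assay and, in place of phenyl, gives a 1.2-fold lower number from compound 2 to compound 3 (0.07 log units; within the scatter) at this same place. Among the compounds shown here, the second of these steps is new information: it is the first reading of the two fluorine atoms on their own, and they move the number by no more than the scatter, so three different aromatic groups at this position now give values that cannot be told apart. The first step adds that the change from 1H-indol-3-yl, which takes away the five-membered ring and the hydrogen-bond donor, also stays within the scatter even when fluorine atoms enter with it, and nothing available explains why these values stay so close.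

Going by these compounds, all three groups at this place are aromatic, so it remains open whether an amine, a carboxylic acid or a longer chain there would stay within this range. On these data alone, it is also open how a single fluorine on the phenyl ring or a pyridyl group would compare.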